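Para-substituted diaryl sulfides: from isopropyl to methanesulfonamido

A few compounds are considered here, and "the series" means these few. Any claim that something is new, unique, unknown or untested is made for them only; others in the source may bear on it.

Measured so far in an assay (Rattus norvegicus) for binding affinity to prostacyclin receptor (Homo sapiens), read by radioligand binding; a lower number here means a stronger inhibitor, a higher number a weaker inhibitor:
compound 1 `COc1ccc(Sc2ccc(NC3=NCCN3)cc2)cc1`: 50.1 nM; 50.1 nM (2 entries)
compound 2 `FC(F)(F)c1ccc(Sc2ccc(NC3=NCCN3)cc2)cc1`: 50.1 nM
compound 3 `CC(C)c1ccc(Sc2ccc(NC3=NCCN3)cc2)cc1`: 251 nM

Compound 3 stands highest of the two single numbers; its nearest neighbour is compound 2, and the step of a 5.0-fold higher number from compound 2 to compound 3 (0.70 log units; beyond the scatter) lies beyond the scatter. Compound 1, with methoxy at the same place, sits at the same number as compound 2. Compound 4 `CS(=O)(=O)Nc1ccc(Sc2ccc(NC3=NCCN3)cc2)cc1` differs from compound 3 by methanesulfonamido in place of isopropyl on an aromatic carbon. Within the data shown here, only the step from compound 2 to compound 3 concerns this position, and it shows that replacing isopropyl there can move the number well beyond the scatter. Compound 4 is therefore expected to return toward the numbers of compounds 1 and 2, an estimated step of a 3.1-fold lower number from compound 3 to compound 4 (0.50 log units; beyond the scatter). For compound 4 the estimate in this assay is 80 nM, within 20 nM to 400 nM.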

Compound 4, inhibition constant: 79.4 nM
For compound 4 the middle estimate is 1.0-fold (0.00 log units) above the measured one, within the range that was stated.
By their numbers in this assay, from the lowest: compounds 2 and 4 (each within the scatter of the next); then compound 3.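

In this assay, methanesulfonamido, para to a large group, brings a 3.2-fold lower number from compound 3 to compound 4 (0.50 log units; beyond the scatter) and is the only group shown here with a hydrogen-bond donor. Trifluoromethyl and methanesulfonamido differ greatly in size and atoms, yet the change gives a 1.6-fold higher number from compound 2 to compound 4 (0.20 log units; within the scatter) and so stays within the scatter. Nothing given here explains either step.

On these data alone, whether an amine, a carboxylic acid or a longer chain at this place would stay with compound 2 and compound 4 or rise toward compound 3 remains open.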